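The source may report more compounds than this note shows. Statements on the series, on what has been measured and on what is new or still open speak of the compounds shown alone.

Compound 1 `CCCCCCC#Cc1cn(C/C=C/CN2C(=O)c3ccccc3C2=O)c(=O)[nH]c1=O` gives 34000 nM in a functional assay on HeLa cells (Homo sapiens) for antiproliferative activity, read by MTT assay, with a stated time of 3 days; a lower number here means a stronger inhibitor, a higher number a weaker inhibitor. Compound 2 `CCCCCCCCC#Cc1cn(C/C=C/CN2C(=O)c3ccccc3C2=O)c(=O)[nH]c1=O` reaches only a limit of this assay, > 100000 nM. Compound 3 `O=C1c2ccccc2C(=O)N1C/C=C\Cn1cc(C#CCCc2ccccc2)c(=O)[nH]c1=O` likewise gives only a limit, > 100000 nM.

Compound 3 therefore stands at the edge of what this assay reports; indeed (the limit of > 100000 nM in this assay, at which 2 of the 3 values shown sit). Among the measured compounds shown here, the single measured step, an at least 2.9-fold higher number from compound 1 to compound 2 (0.46 log units; beyond the scatter), concerns a longer chain and says nothing about double-bond geometry. Compound 4 `O=C1c2ccccc2C(=O)N1C/C=C/Cn1cc(C#CCCc2ccccc2)c(=O)[nH]c1=O` differs from compound 3 in one respect only: the two compounds have the same atoms and bonds and differ only in configuration as drawn: 1 of 1 stereo elements differ; a double bond is drawn Z in compound 3 and E in compound 4. For the measured compounds named here, no measured pair tests this change, so no direction beyond the scatter can be expected from the data; compound 1 shares the geometry of compound 4 and gives a number inside the reported range, which leaves a value near the limit plausible. Compound 4 is estimated at 70000 nM, with a range from 20000 nM to 250000 nM. This expectation amounts to a step of an at least 1.4-fold lower number from compound 3 to compound 4 (0.15 log units; that floor lies within the scatter).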

Compound 4, half-maximal inhibitory concentration: 29000 nM
Estimate against measurement, compound 4: 2.4-fold (0.38 log units) above, within the range that was stated.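

Drawing the double bond E rather than Z gives an at least 3.4-fold lower number from compound 3 to compound 4 (0.53 log units; beyond the scatter) in this assay, so this geometry matters at this position, which the earlier compounds could not show: the fact that compounds 3 and 4 differ only in the configuration as drawn. Compound 3 stands only at a limit of the assay, > 100000 nM. With the E bond kept, phenyl in place of hexyl gives an at least 3.4-fold lower number from compound 2 to compound 4 (0.53 log units; beyond the scatter), while phenyl in place of butyl gives a 1.2-fold lower number from compound 1 to compound 4 (0.07 log units; within the scatter), so these last two chains are not told apart.

From the compounds shown here alone, whether geometry matters equally with the chains of compound 1 and compound 2 remains open, as does how an amine or a carboxylic acid on the chain would fare in this assay.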